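A few compounds are considered here, and "the series" means these few. Any claim that something is new, unique, unknown or untested is made for them only; others in the source may bear on it.

Measured so far in a functional assay for antagonist activity at transient receptor potential cation channel subfamily V member 1 (Homo sapiens); on this read-out lower numbers stand for stronger inhibition and higher numbers for weaker inhibition:
compound 1, `CC(C)(C)CCc1cc(C(F)(F)F)ccc1CNC(=O)Nc1cccc2[nH]ncc12`, gives 4.3 nM
compound 2, `COCCCc1nc(C(F)(F)F)ccc1CNC(=O)Nc1cccc2[nH]ncc12`, gives 12 nM
compound 3, `COCCCc1cc(C(F)(F)F)ccc1CNC(=O)Nc1cccc2[nH]ncc12`, gives 8 nM

Compound 4, `CC(C)(C)CCc1nc(C(F)(F)F)ccc1CNC(=O)Nc1cccc2[nH]ncc12`, is still to be measured in this assay.

Compound 1 is reached from compound 3 by one change, (tert-butyl in place of methoxymethyl on a saturated chain carbon, two bonds along the chain from an aromatic carbon). That step read a 1.9-fold lower number from compound 3 to compound 1 (0.27 log units; within the scatter), so the two values do not separate from each other here. Among the measured compounds shown here, compound 2 is the highest number of the three so far; against compound 3 the gap is within the scatter, against compound 1 it is beyond it. Compound 2 and compound 3 differ in their cores; that difference is not broken down here.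

Compound 4 carries the same change onto the core of compound 2: tert-butyl in place of methoxymethyl on a saturated chain carbon, two bonds along the chain from an aromatic carbon. The place reads the same word for word as in the earlier pair, so this is the same change, seen twice among the four compounds and measured once.

Because the earlier pair gave a 1.9-fold lower number from compound 3 to compound 1 (0.27 log units; within the scatter), a step of about a 1.8-fold lower number from compound 2 to compound 4 (0.27 log units; within the scatter) is expected in this assay for compound 4. The estimate for compound 4 is 6.5 nM, with a likely range from 3 nM to 14 nM.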

Compound 4, half-maximal inhibitory concentration: 5 nM
For compound 4 the middle estimate is 1.3-fold (0.11 log units) above the measured one; the measured number falls inside the stated range.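

On the core of compound 2, 3,3-dimethylbutyl in place of 3-methoxypropyl gives a 2.4-fold lower number from compound 2 to compound 4 (0.38 log units; beyond the scatter) in this assay, so the step reads beyond the scatter on this core. Set beside the earlier step, the change carries from one core to the other with no separable difference in size: the same change on two cores in this assay, a 1.9-fold lower number (0.27 log units; within the scatter) from compound 3 to compound 1 and a 2.4-fold lower number (0.38 log units; beyond the scatter) from compound 2 to compound 4, 1.3-fold (0.11 log units) apart, within the scatter of two such steps. This rests on a single pair for each core, so it shows agreement between these two cores only; it does not explain the step or show that it would hold on any other core.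

Only 3-methoxypropyl and 3,3-dimethylbutyl appear at this place, so the compounds shown leave open how a chain ending in an amine or a carboxylic acid, or a longer chain, would read on either core. Going by these compounds, whether the step keeps its size on a third core also remains open.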